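Lengthening the hydroxycarbamoyl chain: notes on compound 3

The source may report more compounds than this note shows. Statements on the series, on what has been measured and on what is new or still open speak of the compounds shown alone.

Compound 1 `O=C(CCCCC(=O)N1C/C=C/COCc2cccc(c2)-c2ccnc(n2)Nc2cccc(c2)C1)NO` gives 4430 nM
Compound 2 `O=C(CCCCN1C/C=C/CCOc2cccc(c2)-c2ccnc(n2)Nc2cccc(c2)C1)NO` gives 3030 nM

Both values come from a functional assay on HL-60 cells (Homo sapiens) for inhibition, read by CellTiter-Glo, with a stated time of 48 h (a lower number here means a stronger inhibitor of growth, a higher number a weaker inhibitor of growth), and lie within the scatter of each other, so the numbers do not set compound 1 apart from compound 2. Compound 3 `O=C(CCCCCCCC(=O)N1C/C=C/COCc2cccc(c2)-c2ccnc(n2)Nc2cccc(c2)C1)NO` keeps the core of compound 1 and differs in one place, 3-(hydroxycarbamoyl)propyl in place of hydroxycarbamoyl on a saturated chain carbon, four bonds along the chain from a carbonyl carbon with 3-(hydroxycarbamoyl)propyl in place of hydroxycarbamoyl on a saturated chain carbon, four bonds along the chain from a carbonyl carbon.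

For the measured compounds named here, the series holds no measured step between compounds that differ in one place, so the effect of this change has no direct precedent here. The estimate starts from compound 1 at 4430 nM as its anchor and is a judgement rather than a trend. In this assay the expected step is a 3.0-fold lower number from compound 1 to compound 3 (0.47 log units; beyond the scatter) toward a lower number, modest in size and not far beyond the scatter. Compound 3 is estimated at 1500 nM with an expected range from 400 nM to 5000 nM and this range is kept wide on purpose.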

Compound 3, concentration for 50% growth inhibition: 1660 nM
Compound 3: middle estimate off by 1.1-fold (0.04 log units), on the low side; measured number inside the range.
By their numbers in this assay, from the lowest: compounds 3, 2 and 1 (each within the scatter of the next, the first and the last beyond it).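

In this assay, the position on a saturated chain carbon, four bonds along the chain from a carbonyl carbon, proves responsive to the length of the substituent: putting 3-(hydroxycarbamoyl)propyl in place of hydroxycarbamoyl gives a 2.7-fold lower number from compound 1 to compound 3 (0.43 log units; beyond the scatter). For the compounds shown here, this is the first single-place step, and it shows that, on the core of compound 1, the longer hydroxycarbamoyl chain keeps growth inhibition and brings a modest gain that lies beyond the scatter. Nothing measured here bears on why the longer chain gives the lower number.

With only two chain lengths compared on this core, the compounds shown cannot tell whether the number keeps falling as the chain grows, levels off or turns back, so a longer chain such as 6-(hydroxycarbamoyl)hexyl, and lengths short of 3-(hydroxycarbamoyl)propyl, would be the next points to read. They also leave open whether the hydroxycarbamoyl end itself is needed at this position, which a carboxylic acid or a primary amide in its place on the same chain would test.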